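Amide nitrogen substitution: from compound 3 to compound 4

The source may report more compounds than this note shows. Statements on the series, on what has been measured and on what is new or still open speak of the compounds shown alone.

compound 1 `Cn1ccc2ccc(-c3cc(Nc4ccccc4S(N)(=O)=O)cc4nccnc34)cc21`: 37600 nM
compound 2 `Cn1ccc2ccc(-c3cc(Nc4ccccc4S(=O)(=O)NCC4CCOCC4)cc4nccnc34)cc21`: > 100000 nM, a limit of the assay
compound 3 `CNC(=O)c1ccncc1Nc1cc(-c2ccc3ccn(C)c3c2)c2nccnc2c1`: 7020 nM

In an assay on lysate for inhibition of 6-phosphofructo-2-kinase/fructose-2,6-bisphosphatase 3 (Homo sapiens), with stated times of 0.5 min and 45 min (a higher number here means a weaker inhibitor, a lower number a stronger inhibitor), compound 3 gives the lowest of the two numbers shown, with a 5.4-fold lower number from compound 1 to compound 3 (0.73 log units; beyond the scatter). Compound 2 sits at the limit of > 100000 nM in this assay, at which 1 of the 3 values shown sits. Compound 1 to compound 2 shows an at least 2.6-fold higher number from compound 1 to compound 2 (0.42 log units; beyond the scatter), after a substituent entered on a sulfonamide nitrogen.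

Compound 4 `CC(=O)N1CCC(NC(=O)c2ccncc2Nc2cc(-c3ccc4ccn(C)c4c3)c3nccnc3c2)C1` differs from compound 3 by 1-acetylpyrrolidin-3-yl in place of methyl on an amide-type nitrogen. Within the data shown here, only the step from compound 1 to compound 2 concerns a growing nitrogen substituent, and it raised the number; the step from compound 1 to compound 3 changed a different part. A modest rise is therefore expected for compound 4, a 1.7-fold higher number from compound 3 to compound 4 (0.23 log units; within the scatter). Compound 4 is estimated at 12000 nM, between 3500 nM and 45000 nM.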

Compound 4, half-maximal inhibitory concentration: > 100000 nM
Compound 4: a limit, no number; the forecaster's own chance of this, stated with the estimate: 10%; at least 8.3-fold (0.92 log units) between middle value and limit.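

In this assay, the amide-type nitrogen of compound 3 tolerates 1-acetylpyrrolidin-3-yl in place of methyl poorly, with an at least 14-fold higher number from compound 3 to compound 4 (1.15 log units; beyond the scatter). Compound 4 is a limit of the assay, not a number, so only a minimum size can be read for this step, and compound 2 stands at the same limit: the limit of > 100000 nM in this assay, at which 2 of the 4 values shown sit. Methyl thus remains the only substituent on this nitrogen with a readable value.

From the compounds shown here alone, whether the loss follows the pyrrolidine ring or its acetyl group stays open. So does the reading of hydrogen, ethyl or an unacylated pyrrolidin-3-yl amine at this nitrogen.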